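Methoxy to Hydroxy on a Pyrazolyl Urea Pair

The compounds below may be only part of what the source reports. "The series", "measured", "known", "first", "only" and "open" are said of these compounds alone.

Two ureas have been measured. Compound 1 `O=C(Nc1cccc(-n2cc(-c3ccncc3)c(-c3ccc(Cl)c(O)c3)n2)c1)Nc1cccc(C(F)(F)F)c1` gives 1920 nM in a functional assay on MOLT-4 cells (Homo sapiens) for inhibition, read by sulforhodamine B assay, with a stated time of 48 h (a lower number here means a stronger inhibitor of growth, a higher number a weaker inhibitor of growth), and compound 2 `COc1cc(-c2nn(-c3cccc(NC(=O)Nc4ccc(Cl)c(C(F)(F)F)c4)c3)cc2-c2ccncc2)ccc1Cl` gives 1020 nM in the same assay. Compound 2 has the lower of the two numbers, but its gap to compound 1 lies within the scatter, so the two cannot be ordered with confidence.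

Compound 3 `O=C(Nc1cccc(-n2cc(-c3ccncc3)c(-c3ccc(Cl)c(O)c3)n2)c1)Nc1ccc(Cl)c(C(F)(F)F)c1` is not yet measured. It differs from compound 2 in one place: hydrogen in place of methyl on an oxygen on an aromatic ring, that is, methoxy to hydroxy, 4-chloro-3-methoxyphenyl to 4-chloro-3-hydroxyphenyl. Within the data shown here, no measured pair isolates this change, but compound 1 carries the same 4-chloro-3-hydroxyphenyl and lies within the scatter of compound 2. In this assay compound 1 gives 1920 nM. The step from compound 2 to compound 3 is therefore expected to be small, a 1.5-fold higher number from compound 2 to compound 3 (0.17 log units; within the scatter), with no direction beyond the scatter. Compound 3 is estimated at 1500 nM, with a range of 600 nM to 4000 nM.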

Compound 3, concentration for 50% growth inhibition: 777 nM
Estimate against measurement, compound 3: 1.9-fold (0.29 log units) above; the measured number falls inside the stated range.
By their numbers in this assay, from the lowest: compounds 3, 2 and 1 (each within the scatter of the next, the first and the last beyond it).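

The pair of compound 2 and compound 3 now isolates the change from methoxy to hydroxy on the oxygen on an aromatic ring: in this assay it gives a 1.3-fold lower number from compound 2 to compound 3 (0.12 log units; within the scatter), so the two groups cannot be told apart here. With the 4-chloro-3-hydroxyphenyl held fixed, chloro in place of hydrogen on an aromatic carbon gives a 2.5-fold lower number from compound 1 to compound 3 (0.39 log units; beyond the scatter), a modest step and the only one of the two that passes the scatter. No measurement available here accounts for either step.

The compounds shown carry only methoxy and hydroxy on that oxygen, so it remains open whether an ethoxy group, a longer chain or an amine in that place would move the number beyond the scatter. They also leave open whether the chloro step holds when methoxy replaces hydroxy.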